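The compounds below may be only part of what the source reports. "The series", "measured", "known", "first", "only" and "open" are said of these compounds alone.

Three compounds have been measured in an ADME assay on MCF-10A cells (Homo sapiens) for cytotoxicity, read by sulforhodamine B assay, with a stated time of 48 h; on this read-out higher numbers stand for weaker inhibition of growth and lower numbers for stronger inhibition of growth:

compound 1, `O=C1C(=O)N(CN2CCN(c3ccnc4cc(C(F)(F)F)ccc34)CC2)c2cc(Cl)ccc21`, giving 32800 nM
compound 2, `O=C1C(=O)N(CN2CCN(c3ccnc4cc(C(F)(F)F)ccc34)CC2)c2cc(Br)ccc21`, giving 24500 nM
compound 3, `NC(=S)N/N=C1/C(=O)N(CN2CCN(c3ccnc4cc(Cl)ccc34)CC2)c2cc(Cl)ccc21`, giving 64600 nM

Compounds 1 and 2 share one core and differ only by bromo in place of chloro on an aromatic carbon. That change gave a 1.3-fold lower number from compound 1 to compound 2 (0.13 log units; within the scatter), so the two values cannot be told apart here. Compound 3 carries a different core; how the two cores differ is not broken down here. Its number in this assay is the highest of the three, but against compound 1 the gap is within the scatter, while against compound 2 it lies beyond it.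

Compound 4, `NC(=S)N/N=C1/C(=O)N(CN2CCN(c3ccnc4cc(Cl)ccc34)CC2)c2cc(Br)ccc21`, is not yet measured. It differs from compound 3 by bromo in place of chloro on an aromatic carbon. Among the compounds with values here, this is the same change as the one from compound 1 to compound 2, made on the other core at the same kind of position. The step is expected to be small, a 1.3-fold lower number from compound 3 to compound 4 (0.11 log units; within the scatter), because a 1.3-fold lower number from compound 1 to compound 2 (0.13 log units; within the scatter) was the outcome of the same change before. Compound 4 is therefore estimated at 50000 nM, likely between 25000 nM and 100000 nM.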

Compound 4, concentration for 50% growth inhibition: 22100 nM
Beside the measured number, compound 4's estimate is 2.3-fold (0.35 log units) above it; the measured number lies below the stated range.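

In this assay, bromo in place of chloro on an aromatic carbon gives a 2.9-fold lower number from compound 3 to compound 4 (0.47 log units; beyond the scatter) on this second core, a modest step that stands out from the usual scatter. Set beside the earlier step, the two results cannot be told apart: the same change on two cores in this assay, a 1.3-fold lower number (0.13 log units; within the scatter) from compound 1 to compound 2 and a 2.9-fold lower number (0.47 log units; beyond the scatter) from compound 3 to compound 4, 2.2-fold (0.34 log units) apart, within the scatter of two such steps. Within the data shown here, the change therefore carries from one core to the other with no detectable difference in its effect, but this does not show that its size is fixed, since only one of the two steps is clearly larger than the scatter and two cores say nothing about a third.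

The compounds shown hold only chloro and bromo at this place, so it remains open how fluoro, iodo, methyl, methoxy, a nitrile or an amine would behave there. Compounds 1 and 3 differ in more than one place, which leaves the separate contributions of their other groups, such as trifluoromethyl and chloro on the second ring system's side of the molecule, unresolved.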